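Swapping chloro for methoxy on the core of compound 3

The source may hold more compounds than are shown below. What is called first, only, known or untested is meant among the compounds shown, and "the series" means these compounds.

Compound 3 `COC(=O)[C@@]1(C)CCC=C2[C@@H]1CC[C@@H](C)[C@]2(C)Cc1c(C)[nH]c2ccc(Cl)cc12` gives 17000 nM in a functional assay on A549 cells (Homo sapiens) for inhibition, read by sulforhodamine B assay, with a stated time of 48 h; on this read-out higher numbers stand for weaker inhibition of growth and lower numbers for stronger inhibition of growth. Its nearest neighbour on the numbers is compound 2 `COC(=O)[C@@]1(C)CCC=C2[C@@H]1CC[C@@H](C)[C@]2(C)Cc1c(C)[nH]c2ccc(Br)cc12`, which in this assay gives 15000 nM; the step of a 1.1-fold higher number from compound 2 to compound 3 (0.05 log units; within the scatter) lies within the scatter. Compound 1 `COC(=O)[C@@]1(C)CCC=C2[C@@H]1CC[C@@H](C)[C@]2(C)Cc1c(C)[nH]c2ccc(C)cc12`, at 26000 nM in this assay, is the furthest away, yet a 1.5-fold lower number from compound 1 to compound 3 (0.18 log units; within the scatter) and a 1.7-fold lower number from compound 1 to compound 2 (0.24 log units; within the scatter) are within the scatter as well. Compound 4 `COC(=O)[C@@]1(C)CCC=C2[C@@H]1CC[C@@H](C)[C@]2(C)Cc1c(C)[nH]c2ccc(OC)cc12` differs from compound 3 by methoxy in place of chloro on an aromatic carbon. Among the compounds with values here, no measured step carries a methoxy group; the three exchanges on this aromatic carbon, methyl to bromo, methyl to chloro and bromo to chloro, all stayed within the scatter. In this assay the expected step is therefore small, a 1.2-fold higher number from compound 3 to compound 4 (0.07 log units; within the scatter), with nothing beyond the scatter. Compound 4 is estimated at 20000 nM, within 8000 nM to 50000 nM.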

Compound 4, concentration for 50% growth inhibition: 16000 nM
Estimate against measurement, compound 4: 1.3-fold (0.10 log units) above, within the range that was stated.
By their numbers in this assay, from the lowest: compounds 2, 4, 3 and 1 (each within the scatter of the next).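

With methoxy, the exchanges on this aromatic carbon now include a group carrying a hydrogen-bond acceptor, and in this assay every step stays within the scatter: against chloro (a 1.1-fold lower number from compound 3 to compound 4 (0.03 log units; within the scatter)), against bromo (a 1.1-fold higher number from compound 2 to compound 4 (0.03 log units; within the scatter)) and against methyl (a 1.6-fold lower number from compound 1 to compound 4 (0.21 log units; within the scatter)). Methyl, bromo, chloro and methoxy thus cannot be told apart at this place on this read-out. No evidence is available that bears on this result. As far as these compounds go, whether an amine, a carboxylic acid or a longer chain on this carbon would give a step beyond the scatter stays open.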